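Swapping the sulfur substituent in a chalcone-like growth inhibitor

The source may hold more compounds than are shown below. What is called first, only, known or untested is meant among the compounds shown, and "the series" means these compounds.

Three compounds sharing one core were tested in a functional assay on DU-145 cells (Homo sapiens) for inhibition, read by trypan blue exclusion, with a stated time of 96 h; on this read-out lower numbers stand for stronger inhibition of growth and higher numbers for weaker inhibition of growth. Compound 1 `Cc1ccc(S/C(=C/c2ccc(Br)cc2)C(=O)c2ccc(Cl)cc2)cc1` gives 25000 nM, compound 2 `Cc1ccc(S/C(=C/c2ccc(Cl)cc2)C(=O)c2ccc(Cl)cc2)cc1` gives 10000 nM, and compound 3 `CN(C)c1ccc(/C=C(/SCc2ccc(F)cc2)C(=O)c2ccc(Cl)cc2)cc1` gives 50000 nM, the highest of the three, close to compound 1 and well apart from compound 2. Going by the values given here, the only single-point step measured is a 2.5-fold lower number from compound 1 to compound 2 (0.40 log units; beyond the scatter), which concerns the aromatic halogen and not the sulfur. Compound 4 `Cc1ccc(S/C(=C/c2ccc(N(C)C)cc2)C(=O)c2ccc(Cl)cc2)cc1` differs from compound 3 by 4-methylphenyl in place of 4-fluorobenzyl on a sulfur. Among the compounds with values here, no measured pair isolates this change, so the expectation rests on the spread of the three numbers. Compound 4 is expected at 25000 nM, within 8000 nM to 80000 nM, which means an estimated 2.0-fold lower number from compound 3 to compound 4 (0.30 log units; within the scatter).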

Compound 4, concentration for 50% growth inhibition: > 100000 nM
Compound 4 ended at the assay's limit; the forecaster's own chance of this, stated with the estimate: 10%; middle value at least 4.0-fold (0.60 log units) away from the limit.
By their numbers in this assay, from the lowest: compound 2; then compounds 1 and 3 (each within the scatter of the next). At a limit, above all of these: compound 4.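

Compound 4 gives a limit and not a number: the limit of > 100000 nM in this assay, at which 1 of the 4 values shown sits. On the sulfur, the change to 4-methylphenyl gives an at least 2.0-fold higher number from compound 3 to compound 4 (0.30 log units; that floor lies within the scatter), so this floor alone does not show that the swap matters. With 4-methylphenyl on the sulfur, replacing the halogen with dimethylamino on the aromatic carbon gives an at least 10-fold higher number from compound 2 to compound 4 (1.00 log units; beyond the scatter) and an at least 4.0-fold higher number from compound 1 to compound 4 (0.60 log units; beyond the scatter), so this aromatic position tolerates dimethylamino less well than either halogen in this series.

From the compounds shown here alone, how far compound 4 lies past the limit stays open. So does how a plain benzyl or a 4-fluorophenyl group on the sulfur would read.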